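The source may hold more compounds than are shown below. What is called first, only, known or untested is meant among the compounds shown, and "the series" means these compounds.

Among the measured compounds shown here, in a physicochemical assay for solubility, in phosphate buffer, at pH 7.4 (on this read-out higher numbers stand for higher solubility and lower numbers for lower solubility), compound 1 (`CC(C)n1nc(-c2ccnc3[nH]c(C4CCN(CC(=O)N(C)C)CC4)cc23)ccc1=O`) gives 11000 nM, the lower of the two numbers so far and beyond the scatter from compound 2 (`CN(C)C(=O)CN1CCC(c2cc3c(-c4ccc(=O)n(C5CCOCC5)c4)ccnc3[nH]2)CC1`), which gives 840000 nM. Compound 3 (`COc1cc(=O)n(C)cc1-c1ccnc2[nH]c(C3CCN(CC(=O)N(C)C)CC3)cc12`) is not yet measured. It keeps the core of compound 1 and differs in one place, on an aromatic carbon opposite the ring nitrogen: a group of 10 heavy atoms (7 carbon, 1 nitrogen, 2 oxygen; one six-membered aromatic ring with 1 hetero atom) in place of a group of 10 heavy atoms (7 carbon, 2 nitrogen, 1 oxygen; one six-membered aromatic ring with 2 hetero atoms), on an aromatic carbon. For the measured compounds named here, no measured step covers this change, so the expectation rests only on the span between those two values. In this assay the expected step is a 6.4-fold higher number from compound 1 to compound 3 (0.80 log units; beyond the scatter), upward and beyond the scatter. Compound 3 is estimated at 70000 nM, with an expected range of 12000 nM to 400000 nM.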

Compound 3, solubility: 670000 nM
The estimate for compound 3 lay 9.6-fold (0.98 log units) below the measured number; the measured number lies above the stated range.
By their numbers in this assay, from the lowest: compound 1; then compounds 3 and 2 (each within the scatter of the next).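

At the aromatic carbon opposite the ring nitrogen, replacing the six-membered aromatic ring with 2 hetero atoms by the one with 1 hetero atom gives in this assay a 61-fold higher number from compound 1 to compound 3 (1.78 log units; beyond the scatter) with heavy atoms, donors and acceptors unchanged in number. Among the compounds shown here, this is the first single-place step read here, and it shows that this position can move the read-out by a large amount. Nothing measured accounts for the size of the step. The hetero atom count and the ring's substituents change together, so their shares cannot be separated. Going by these compounds, whether a hydroxyl, an amine or a longer alkoxy chain on the entering ring would keep the higher number remains open.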